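Methyl Added to a Weak Dimethylamino Analogue

A few compounds are considered here, and "the series" means these few. Any claim that something is new, unique, unknown or untested is made for them only; others in the source may bear on it.

The series shares an aminoquinoline-type core carrying an aryl group, and potency is read in a functional assay on PC-3 cells (Homo sapiens) for cytotoxicity, read by sulforhodamine B assay; a higher number here means a weaker inhibitor, a lower number a stronger inhibitor. Compound 1 `COc1cccc(-c2cc3cc(OC)c(OC)cc3c(N)n2)c1` gives 180 nM in this assay, and compound 2 `COc1cc2cc(-c3ccccc3C)nc(N)c2cc1OC` gives 1250 nM. Compound 3 `CN(C)c1cccc2c(N)nc(-c3ccccc3)cc12` carries a dimethylamino group on its core in place of the two methoxy groups of the others; in this assay compound 3 reaches only the limit of > 10000 nM, so no number is known for it. It sits at the limit of > 10000 nM in this assay, at which 1 of the 3 values shown sits.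

Compound 4 `Cc1ccccc1-c1cc2c(N(C)C)cccc2c(N)n1` differs from compound 3 by methyl in place of hydrogen on an aromatic carbon, the same change that, viewed one bond further out, turns phenyl into 2-methylphenyl. Compound 3 is already beyond the reach of this assay, and a single methyl on the aryl group gives no ground to expect a step into the measurable range; the expected step that the limit leaves unreadable from compound 3 to compound 4 is none beyond the scatter. Compound 4 is therefore expected to give about 15000 nM, within 5000 nM to 50000 nM, most likely again reported only as a limit.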

Compound 4, half-maximal inhibitory concentration: > 10000 nM
Compound 4 ended at the assay's limit; the forecaster's own chance of this, stated with the estimate: 65%; the middle value does not contradict the limit.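

In this assay compound 4 gives > 10000 nM, which is a limit and not a number. Compound 3 stands at the same limit, so no step can be read between compound 3 and compound 4. The compounds shown leave open what methyl in place of hydrogen does to a compound with a readable value.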